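A Formyl for Hydroxymethyl Swap in an Inactive Series

This account rests on a few compounds, and the source may have more. Where it says the series, first, only, none or still open, it means among the compounds named here.

Compound 1 `Cn1c(Cc2nn(CCC=O)c(=O)c3ccccc23)nnc1SCC(=O)Nc1ccc(Cl)cc1Cl` and compound 2 `Cn1c(Cc2nn(CCCO)c(=O)c3ccccc23)nnc1SCC(=O)Nc1ccc(Cl)cc1Cl` share a core and differ in one place only, while compound 3 `Cn1c(Cc2nn(CCCO)c(=O)c3ccccc23)nnc1SCCCCCCCC(=O)Nc1ccc(Cl)cc1Cl` carries a longer chain; the difference between the cores of compound 2 and compound 3 is not broken down here. In an assay on NK92 cells for inhibition of interleukin-2 (Homo sapiens), read by AlphaScreen, with stated times of 30 min and 1 h (a higher number here means a weaker inhibitor, a lower number a stronger inhibitor), compound 1 reaches only a limit, > 30000 nM. Compound 2 likewise gives only a limit in this assay, > 30000 nM. Compound 3 also gives only a limit in this assay, > 30000 nM. The change from compound 2 to compound 1 is formyl in place of hydroxymethyl on a saturated chain carbon, two bonds along the chain from an aromatic nitrogen, and its step that the two limits leave unreadable from compound 2 to compound 1 cannot be sized because of the limit of > 30000 nM in this assay, at which 3 of the 3 values shown sit. Compound 4 `Cn1c(Cc2nn(CCC=O)c(=O)c3ccccc23)nnc1SCCCCCCCC(=O)Nc1ccc(Cl)cc1Cl` is compound 3 carrying the same change, (formyl in place of hydroxymethyl on a saturated chain carbon, two bonds along the chain from an aromatic nitrogen). Compound 3 itself sits at a limit, and the earlier instance of this change, a step that the two limits leave unreadable from compound 2 to compound 1, left both partners at that limit, so the result for compound 4 is expected to remain unreadable as well. The expected step is a step that the limit leaves unreadable from compound 3 to compound 4. The estimate for compound 4 in this assay is 50000 nM, expected to fall between 20000 nM and 200000 nM.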

Compound 4, half-maximal inhibitory concentration: 21900 nM
Compound 4: the middle estimate sits 2.3-fold (0.36 log units) above what was measured; low and high end bracket the measured number.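

In this assay, putting formyl in place of hydroxymethyl on the core with the longer chain gives an at least 1.3-fold lower number from compound 3 to compound 4 (0.13 log units; that floor lies within the scatter). This size is only a floor and lies within the usual scatter, which means a real difference is not shown. Compound 4 itself gives a measured number, 21900 nM. Whether the change carries from one core to the other cannot be judged, because the step from compound 2 to compound 1 cannot be read, with both partners at a limit: the limit of > 30000 nM in this assay, at which 3 of the 4 values shown sit.

The compounds shown leave open what other groups at the end of this chain would do, such as an amine or a carboxylic acid. Also open, as far as these compounds go, is the true size of the step to compound 4, which would need a number for compound 3 in place of its limit, and whether formyl behaves the same way on further cores.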